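Ester to Amide on the Shared Core

The compounds below may be only part of what the source reports. "The series", "measured", "known", "first", "only" and "open" are said of these compounds alone.

Compound 1 `COc1ccc2c(c1)OC(c1cc(OC)c(OC)c(OC)c1)C(C(=O)OC(C)C)=C2` gives 11800 nM in a functional assay for inhibition of nuclear factor NF-kappa-B complex (Homo sapiens) (a lower number here means a stronger inhibitor, a higher number a weaker inhibitor), the lowest of the two numbers measured, though compound 2 `COC(=O)C1=Cc2ccc(OC)cc2OC1c1cc(OC)c(OC)c(OC)c1` at 13800 nM lies within the scatter of it. Compound 3 `COc1ccc2c(c1)OC(c1cc(OC)c(OC)c(OC)c1)C(C(=O)NC(C)C)=C2` differs from compound 1 by isopropylamino in place of isopropoxy on a carbonyl carbon. Going by the values given here, the only measured step, a 1.2-fold higher number from compound 1 to compound 2 (0.07 log units; within the scatter), alters the same carbonyl-bearing group but not the oxygen-to-nitrogen exchange, so it bears on the change only loosely and suggests this position tolerates variation. Among the compounds with values here, with no direct precedent, a step of a 1.0-fold higher number from compound 1 to compound 3 (0.01 log units; within the scatter) is expected, giving an estimate for compound 3 of 12000 nM, with a range from 4000 nM to 36000 nM.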

Compound 3, half-maximal inhibitory concentration: > 50000 nM
Compound 3 was reported as a limit; the forecaster's own chance of this, stated with the estimate: 10%; middle value at least 4.1-fold (0.61 log units) away from the limit.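

Isopropylamino in place of isopropoxy on a carbonyl carbon gives an at least 4.2-fold higher number from compound 1 to compound 3 (0.62 log units; beyond the scatter), and isopropylamino in place of methoxy gives an at least 3.6-fold higher number from compound 2 to compound 3 (0.55 log units; beyond the scatter). Compound 3 is reported only as a limit: the limit of > 50000 nM in this assay, at which 1 of the 3 values shown sits. The two esters left this position looking tolerant in this assay, but exchanging the ester oxygen for nitrogen, with the isopropyl kept, moves the number beyond the scatter.

From the compounds shown here alone, the full size of these steps stays open. So does whether a dimethylamide or a carboxylic acid on the same carbonyl carbon would behave like the esters or like compound 3.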